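The source may report more compounds than this note shows. Statements on the series, on what has been measured and on what is new or still open speak of the compounds shown alone.

Measured compounds and their readings:

compound 1, `Cc1ccc(N2CCN(CC(=O)N(c3ccccc3)c3ccccc3)CC2)cc1`: in a toxicity assay on the whole organism (strain albino) for activation, with Mus musculus as the target, with stated times of 30 min and 240 min (on this read-out higher numbers stand for an effect only at larger amounts of compound and lower numbers for an effect already at smaller amounts), compound 1 gives > 40 mg/kg, which is a limit of the assay and not a number.
compound 2, `Cc1cccc(N2CCN(CC(=O)N(c3ccccc3)c3ccccc3)CC2)c1C`: in this assay compound 2 gives > 40 mg/kg, again a limit of the assay.
compound 3, `COc1cccc(N2CCN(CC(=O)N(c3ccccc3)c3ccccc3)CC2)c1`: in this assay compound 3 gives 55.4 mg/kg.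

Compound 2 stands at the limit of > 40 mg/kg in this assay, at which 2 of the 3 values shown sit, so its position relative to the others cannot be read off. Going by the values given here, the step that the two limits leave unreadable from compound 1 to compound 2 is not readable, nor is a step that the limit leaves unreadable from compound 1 to compound 3 or a step that the limit leaves unreadable from compound 2 to compound 3; only the numerical reading of compound 3 sits near the limit region, and no step among the measured compounds is readable as beyond the scatter.

Compound 4, `O=C(CN1CCN(c2cccc(Cl)c2)CC1)N(c1ccccc1)c1ccccc1`, differs from compound 2 by 3-chlorophenyl in place of 2,3-dimethylphenyl on an amine nitrogen in a ring. Among the compounds with values here, none of the measured steps gives a readable size for a change of this kind. Compound 4 is therefore expected to sit close to where compound 2 and compound 3 sit, with the step that the limit leaves unreadable from compound 2 to compound 4 expected to be none beyond the scatter. The estimate for compound 4 in this assay is 50 mg/kg, between 30 mg/kg and 90 mg/kg, with a fair chance that only a limit is reported.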

Compound 4, dose for half-maximal effect: 48.4 mg/kg
For compound 4 the middle estimate is 1.0-fold (0.01 log units) above the measured one, and the stated range covers the measured number.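

In this assay, going by these compounds alone, chloro in place of methoxy on an aromatic carbon is a 1.1-fold lower number from compound 3 to compound 4 (0.06 log units; within the scatter), the first step with a number at both ends. The 3-chlorophenyl and 3-methoxyphenyl groups, each on an amine nitrogen in a ring, are therefore not told apart by this read-out, so this one exchange on the aromatic ring leaves the reading within the scatter. The steps from compound 1 and from compound 2 to compound 4 cannot be read, because compound 1 and compound 2 each carry a limit of the assay and not a number: the limit of > 40 mg/kg in this assay, at which 2 of the 4 values shown sit.

Still open, as far as these compounds go, is whether a group of another kind on that aromatic carbon, such as an amine or a carboxylic acid, would give a step beyond the scatter in this assay. Also open, from the compounds shown here alone, are the numerical standing of the 4-methylphenyl and 2,3-dimethylphenyl compounds, and whether a longer chain joining the amide carbonyl to the ring nitrogen would change the reading.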